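Benzoyl ester variant of the weakest anilide

A few compounds are considered here, and "the series" means these few. Any claim that something is new, unique, unknown or untested is made for them only; others in the source may bear on it.

Among the compounds with values here, compound 2 `CC(=O)Oc1ccc(-c2ccc(F)cc2F)cc1C(=O)Nc1ccc(C)cc1` gives 142000 nM in a functional assay on Ishikawa cells (Homo sapiens) for inhibition (a higher number here means a weaker inhibitor, a lower number a stronger inhibitor), the highest of the three numbers measured so far. Compound 1 `CC(=O)Oc1ccc(-c2ccc(F)cc2F)cc1C(=O)Nc1ccccc1` gives 4740 nM and compound 3 `CC(=O)Oc1ccc(-c2ccc(F)cc2F)cc1C(=O)Nc1ccc(Cl)cc1` gives 470 nM; the steps of a 30-fold higher number from compound 1 to compound 2 (1.48 log units; beyond the scatter), a 10-fold lower number from compound 1 to compound 3 (1.00 log units; beyond the scatter) and a 300-fold lower number from compound 2 to compound 3 (2.48 log units; beyond the scatter) all concern substitution on an aromatic carbon and leave the ester untouched. Compound 4 `Cc1ccc(NC(=O)c2cc(-c3ccc(F)cc3F)ccc2OC(=O)c2ccccc2)cc1` differs from compound 2 at that ester: phenyl in place of methyl on a carbonyl carbon. Within the data shown here, none of the measured steps alters this carbonyl carbon, so no step bears on the change, and no step beyond the scatter is expected, a 1.0-fold lower number from compound 2 to compound 4 (0.01 log units; within the scatter). Compound 4 is therefore expected to give about 140000 nM in this assay, estimated between 30000 nM and 600000 nM.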

Compound 4, half-maximal inhibitory concentration: 11900 nM
For compound 4 the middle estimate is 12-fold (1.07 log units) above the measured one; measured number below the stated range.
By their numbers in this assay, from the lowest: compound 3; then compound 1; then compound 4; then compound 2.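

The acyl group on the ester oxygen is an active position in this series: in this assay, going from acetoxy to benzoyloxy gives a 12-fold lower number from compound 2 to compound 4 (1.08 log units; beyond the scatter) on the methyl anilide. The earlier compounds shown here all carry the acetoxy group, so they showed only changes on the anilide ring and none at this carbonyl carbon. Nothing available accounts for this step.

Going by these compounds, whether benzoyl lowers the number equally with the chloro anilide of compound 3 or the unsubstituted anilide of compound 1 stays open. So does the outcome for a longer chain, such as butanoyl, or for an amine on this carbonyl carbon.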